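A few compounds are considered here, and "the series" means these few. Any claim that something is new, unique, unknown or untested is made for them only; others in the source may bear on it.

In a toxicity assay on MT4 cells (Homo sapiens) for cytotoxicity, read by MTT assay (on this read-out lower numbers stand for higher toxicity in this test and higher numbers for lower toxicity in this test), compound 1 `Cc1cc(-c2ccccc2)cc(C)c1Oc1cc(N)nc(Nc2ccc(C#N)cc2)n1` reads 25600 nM and compound 2 `Cc1cc(-c2cccc(F)c2)cc(C)c1Oc1cc(N)nc(Nc2ccc(C#N)cc2)n1` reads 24700 nM while compound 3 `Cc1ccccc1-c1cc(C)c(Oc2cc(N)nc(Nc3ccc(C#N)cc3)n2)c(C)c1` reads 25600 nM and so stands level with compound 1 at the digits shown, with all three within the scatter of one another. Compound 4 `Cc1cc(-c2cccc(C#N)c2)cc(C)c1Oc1cc(N)nc(Nc2ccc(C#N)cc2)n1` is the next to be read. It carries 3-cyanophenyl in place of 2-methylphenyl on an aromatic carbon and the rest of the structure stays as in compound 3. Going by the values given here, three measured steps bear on this change. Fluoro in place of hydrogen gave a 1.0-fold lower number from compound 1 to compound 2 (0.02 log units; within the scatter) and methyl in place of hydrogen gave no change at the digits printed from compound 1 to compound 3 (within the scatter) while 2-methylphenyl in place of 3-fluorophenyl gave a 1.0-fold higher number from compound 2 to compound 3 (0.02 log units; within the scatter) so that none of these changes moved the number beyond the scatter. Among the compounds with values here, no measured compound carries 3-cyanophenyl, which leaves the expectation an extrapolation. The expected change is a 1.1-fold lower number from compound 3 to compound 4 (0.03 log units; within the scatter) and thus no step beyond the scatter is expected in this assay here. For compound 4 the estimate is 24000 nM (expected range 12000 nM to 45000 nM).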

Compound 4, half-maximal cytotoxic concentration: 20200 nM
Compound 4: middle estimate off by 1.2-fold (0.07 log units), on the high side; low and high end bracket the measured number.
By their numbers in this assay, from the lowest: compounds 4, 2, 1 and 3 (each within the scatter of the next).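

In this assay the 3-cyanophenyl group brings a nitrile to this position, and 3-cyanophenyl counts a hydrogen-bond acceptor where 2-methylphenyl counts none, yet compound 4 stays within the scatter of all three earlier compounds. The steps are a 1.3-fold lower number from compound 3 to compound 4 (0.10 log units; within the scatter) and a 1.2-fold lower number from compound 2 to compound 4 (0.09 log units; within the scatter) and also a 1.3-fold lower number from compound 1 to compound 4 (0.10 log units; within the scatter) so a nitrile joins fluoro and methyl among the changes on this aryl ring that leave the read-out within the scatter. Nothing available explains why the read-out holds so steady across these changes.

This holds only for the four compounds shown, all of which keep an aromatic ring of carbon only at this position. Going by these compounds, whether an amine or a carboxylic acid on that ring, or a longer chain in place of it, would move the number beyond the scatter remains open.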